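Nitrophenyl swap on compound 2: working notes

The source may report more compounds than this note shows. Statements on the series, on what has been measured and on what is new or still open speak of the compounds shown alone.

Three compounds have readings in a functional assay on RS4-11 cells (Homo sapiens) for inhibition, read by CCK-8 assay, with a stated time of 48 h; a lower number here means a stronger inhibitor, a higher number a weaker inhibitor. Compound 1 `COc1ccc(NC(=O)NCCNS(=O)(=O)c2ccc(-c3ccccc3OCc3ccccc3)s2)cc1` gives > 20000 nM, which is a limit of the assay and not a number. Compound 2 `Cc1cc(C)cc(NC(=O)NCCNS(=O)(=O)c2ccc(-c3ccccc3Oc3ccc([N+](=O)[O-])c([N+](=O)[O-])c3)s2)c1` gives 3600 nM, and compound 3 `Cc1ccc(-c2ccsc2S(=O)(=O)NCCNC(=O)Nc2cc(C(F)(F)F)cc(C(F)(F)F)c2)c(Oc2ccc(O)c(O)c2)c1` gives 5600 nM. These two numbers lie within the usual scatter of each other, so compound 2 sits level with compound 3. Compound 4 `O=C(NCCNS(=O)(=O)c1ccc(-c2ccccc2Oc2ccc([N+](=O)[O-])c([N+](=O)[O-])c2)s1)Nc1ccc([N+](=O)[O-])cc1` has not been measured. It carries 4-nitrophenyl in place of 3,5-dimethylphenyl on an amide-type nitrogen. Within the data shown here, no measured pair isolates this change. The estimated 1.7-fold higher number from compound 2 to compound 4 (0.22 log units; within the scatter) stays within the scatter in this assay, leaning toward a higher number. For compound 4 the expected value is 6000 nM, with an estimated range of 2500 nM to 16000 nM.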

Compound 4, half-maximal inhibitory concentration: 3000 nM
Beside the measured number, compound 4's estimate is 2.0-fold (0.30 log units) above it; measured number inside the range.
By their numbers in this assay, from the lowest: compounds 4, 2 and 3 (each within the scatter of the next). At a limit, above all of these: compound 1.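

In this series, 4-nitrophenyl in place of 3,5-dimethylphenyl on an amide-type nitrogen gives a 1.2-fold lower number from compound 2 to compound 4 (0.08 log units; within the scatter) in this assay and forms the first pair differing in one place. The position therefore takes a nitro-bearing phenyl as readily as a dimethyl-bearing one, with compound 2 and compound 4 level. No evidence at hand bears on this step.

On these data alone, whether any group on this nitrogen moves the reading beyond the scatter stays open. An aminophenyl, a carboxyphenyl or a saturated cyclohexyl there would test this.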